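The compounds below may be only part of what the source reports. "The series", "measured", "known", "first", "only" and "open" are said of these compounds alone.

Of the compounds shown here, three have so far been measured in an assay on CHO cells for inhibition of sphingosine kinase 1 (Homo sapiens), tested at 10 uM; on this read-out lower numbers stand for less inhibition and higher numbers for more inhibition at the one concentration tested (going by the name of the read-out). Compound 1 `CCCCC#C[C@@H](O)[C@H](C)N` gives 4.85% in this assay. Compound 2 `CCCCCCC(=O)[C@@H]1COC(C)(C)N1C(=O)OC(C)(C)C` gives 4.71% in this assay. Compound 3 `CCCCCCCCC#C[C@@H](O)[C@@H](N)CO` gives 13.7% in this assay. The number for compound 2 differs from that of compound 1 and from that of compound 3 by amounts that stay within the usual scatter of such measurements, so the three cannot be placed in any order and all sit low on this read-out.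

Compound 4 `CCCCC#CC(=O)[C@@H]1COC(C)(C)N1C(=O)OC(C)(C)C` has not yet been measured in this assay. It differs from compound 2 in one place: hex-1-yn-1-yl in place of hexyl on a carbonyl carbon. Among the compounds with values here, no two measured compounds differ by a change of this kind, so there is no measured step to lean on. Because compound 2 gives 4.71% and the other two compounds sit in the same low range, the step expected is a number 1.3 percentage points higher from compound 2 to compound 4 (within the scatter), none beyond the scatter. Compound 4 is therefore estimated at 6%, between -5% and 20%.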

Compound 4, a percentage reported as inhibition, at one concentration (the size of the read-out at that concentration, not a potency): 9.08%
Compound 4: middle estimate off by 3.1 percentage points, on the low side; low and high end bracket the measured number.
By their numbers in this assay, from the lowest: compounds 2, 1, 4 and 3 (each within the scatter of the next).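

In this assay, within the data shown here, hex-1-yn-1-yl in place of hexyl on a carbonyl carbon gives a number 4.4 percentage points higher from compound 2 to compound 4 (within the scatter), the first step that can be read at this place. Swapping this saturated chain for one of the same heavy-atom count with one triple bond therefore leaves the read-out within the scatter, and both compounds stay low at the one concentration tested. No measurement shown here offers an explanation for the size of this step.

The compounds shown leave open whether a different group on this carbonyl carbon, such as a longer chain, a phenyl ring or an amine, would move the number beyond the scatter. Among these compounds, also open is whether the same exchange would give a similar step on a core other than the one shared by compound 2 and compound 4.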